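Lengthening the hydroxy chain from compound 3 to compound 4

The compounds below may be only part of what the source reports. "The series", "measured", "known", "first", "only" and "open" are said of these compounds alone.

Three compounds were measured in an ADME assay on HEK293 cells (Homo sapiens) for cytotoxicity, read by MTT assay, with a stated time of 48 h (a lower number here means a stronger inhibitor, a higher number a weaker inhibitor), as follows
Compound 1 `N#Cc1nc2c(-c3nc4ccccc4[nH]3)c(N)n(CCN3CCCC3)c2nc1C#N` gives 18300 nM
Compound 2 `CN1CCN(CCn2c(N)c(-c3nc4ccccc4[nH]3)c3nc(C#N)c(C#N)nc32)CC1` gives 10900 nM
Compound 3 `N#Cc1nc2c(-c3nc4ccccc4[nH]3)c(N)n(CCO)c2nc1C#N` gives > 50000 nM as a limit

For compound 3 the reading of > 50000 nM is a limit of this assay and not a number. Compound 4 `N#Cc1nc2c(-c3nc4ccccc4[nH]3)c(N)n(CCCO)c2nc1C#N` differs from it by a single change (hydroxymethyl in place of hydroxy on a saturated chain carbon, two bonds along the chain from an aromatic nitrogen), hydroxymethyl in place of hydroxy on a saturated chain carbon, two bonds along the chain from an aromatic nitrogen. The same difference reads 2-hydroxyethyl to 3-hydroxypropyl. For the measured compounds named here, no measured step lengthens this chain, so the nearest evidence comes from changes at the same place. Going to the hydroxy end gave an at least 2.7-fold higher number from compound 1 to compound 3 (0.43 log units; beyond the scatter) and also an at least 4.5-fold higher number from compound 2 to compound 3 (0.66 log units; beyond the scatter), while exchanging the two ring groups gave a 1.7-fold lower number from compound 1 to compound 2 (0.23 log units; within the scatter). With the hydroxy end kept, compound 4 is expected to stay close to compound 3 rather than approach compound 2 at 10900 nM. No step beyond the scatter is expected, and the estimated step is a number no higher from compound 3 to compound 4 (the limit leaves the size open) in this assay. For compound 4 the estimate is 50000 nM, with an expected range from 25000 nM to 90000 nM.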

Compound 4, half-maximal inhibitory concentration: > 50000 nM
Compound 4: only a limit was reported; the forecaster's own chance of this, stated with the estimate: 65%; the middle value sits exactly at the limit.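

In this assay the hydroxy end now appears on a second chain length, the 3-hydroxypropyl group as well as the 2-hydroxyethyl group, and the gap to the chains ending in a ring holds, with an at least 4.5-fold higher number from compound 2 to compound 4 (0.66 log units; beyond the scatter) and an at least 2.7-fold higher number from compound 1 to compound 4 (0.43 log units; beyond the scatter). Before this, that gap rested on compound 3 alone. The step from 2-hydroxyethyl to 3-hydroxypropyl itself cannot be read, because compound 3 and compound 4 both stand at a limit and not at a number: the limit of > 50000 nM in this assay, at which 2 of the 4 values shown sit.

From the compounds shown here alone, whether the added carbon changes the reading at all therefore stays open, as does how far compound 3 and compound 4 lie from each other. Also open, going by these compounds, is what a primary amine or a carboxylic acid in place of the hydroxy end, or a still longer chain, would read in this assay.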